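A few compounds are considered here, and "the series" means these few. Any claim that something is new, unique, unknown or untested is made for them only; others in the source may bear on it.

Three compounds share one core. Compound 1 `O=C1c2c[n+]([O-])c3ccccc3c2C(=O)c2[nH]c3ccccc3c21` carries hydrogen on an aromatic nitrogen, and in a functional assay on SH-SY5Y cells (Homo sapiens) for cytotoxicity, read by MTT assay, with a stated time of 72 h (on this read-out higher numbers stand for weaker inhibition and lower numbers for stronger inhibition), compound 1 gives 1380 nM. Compound 2 `O=C1c2c[n+]([O-])c3ccccc3c2C(=O)c2c1c1ccccc1n2Cc1cn([C@@H]2C[C@H](O)[C@@H](CO)O2)nn1` gives 150 nM, and compound 3 `O=C1c2c[n+]([O-])c3ccccc3c2C(=O)c2c1c1ccccc1n2CCCCN1CCCCC1` gives 230 nM, the second highest of the three numbers, within the scatter of compound 2 and separated from compound 1 by a 6.0-fold lower number from compound 1 to compound 3 (0.78 log units; beyond the scatter). Compound 4 `CCCCN1CCN(CCCCn2c3c(c4ccccc42)C(=O)c2c[n+]([O-])c4ccccc4c2C3=O)CC1` differs from compound 3 by 4-butylpiperazin-1-yl in place of piperidin-1-yl on a saturated chain carbon, four bonds along the chain from an aromatic nitrogen. For the measured compounds named here, the only measured step, a 6.0-fold lower number from compound 1 to compound 3 (0.78 log units; beyond the scatter), concerns adding the whole 4-(piperidin-1-yl)butyl chain to hydrogen, not exchanging piperidin-1-yl for 4-butylpiperazin-1-yl; no measured pair shows that exchange. The number for compound 4 is therefore expected to stay close to that of compound 3, no change at the digits printed from compound 3 to compound 4 (within the scatter), with no step beyond the scatter. Compound 4 is estimated at 230 nM, between 80 nM and 700 nM.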

Compound 4, half-maximal inhibitory concentration: 6100 nM
For compound 4 the middle estimate is 27-fold (1.42 log units) below the measured one; measured number above the stated range.
By their numbers in this assay, from the lowest: compounds 2 and 3 (each within the scatter of the next); then compound 1; then compound 4.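

At the end of the chain, four bonds along from an aromatic nitrogen, the choice of ring matters a great deal in this assay: 4-butylpiperazin-1-yl in place of piperidin-1-yl gives a 27-fold higher number from compound 3 to compound 4 (1.42 log units; beyond the scatter). The earlier compounds shown here showed only the whole chain replacing hydrogen, so a butyl chain alone does not guarantee a low number; the group at its end counts too. No available evidence explains this rise. As far as these compounds go, whether it follows the extra ring nitrogen or the added butyl group stays open; an unsubstituted piperazin-1-yl or a 4-methylpiperazin-1-yl end would help separate them.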